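Swapping a methylpiperazinyl for methylsulfanyl on the shared core

The compounds below may be only part of what the source reports. "The series", "measured", "known", "first", "only" and "open" are said of these compounds alone.

Measured so far:
- compound 1, `COc1ccc(NC(=O)CSc2nc3ccc(N4CCN(C)CC4)nc3[nH]2)cc1OC`: 35%
- compound 2, `COc1ccc(NC(=O)CCSc2nc3cccnc3[nH]2)cc1OC`: 13%
- compound 3, `COc1cc(NC(=O)CSc2nc3cccnc3[nH]2)cc(OC)c1`: 38%

In an assay on isolated protein for inhibition of Ectonucleotide pyrophosphatase/phosphodiesterase family member 1 (Homo sapiens), tested at 10 uM (on this read-out lower numbers stand for less inhibition and higher numbers for more inhibition at the one concentration tested (going by the name of the read-out)), compound 1 gives 35%, the second highest of the three numbers. Compound 3 gives 38%, a number that lies within the scatter of compound 1, so the two cannot be ordered. Compound 2 gives 13%, which lies beyond the scatter below compound 1. No two of the measured compounds differ in one place only, so no single change can be read from these numbers.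

Compound 4, `COc1ccc(NC(=O)CSc2nc3ccc(SC)nc3[nH]2)cc1OC`, has not been measured. It differs from compound 1 in one place: methylsulfanyl in place of 4-methylpiperazin-1-yl on an aromatic carbon. Going by the values given here, nothing among the measured compounds shows what a group at this place contributes, since compound 3 and compound 2 also differ from compound 1 elsewhere. The expected step from compound 1 to compound 4 is therefore a number 5 percentage points lower from compound 1 to compound 4 (within the scatter), a change that is not expected to go beyond the scatter in either direction. In this assay compound 4 is estimated to give 30%, with a range from 10% to 55%.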

Compound 4, a percentage reported as inhibition, at one concentration (the size of the read-out at that concentration, not a potency): 59%
The estimate for compound 4 lay 29 percentage points below the measured number; the whole stated range lies below it.
By their numbers in this assay, from the lowest: compound 2; then compounds 1 and 3 (each within the scatter of the next); then compound 4.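

With methylsulfanyl in place of 4-methylpiperazin-1-yl on the aromatic carbon next to the ring nitrogen, this assay shows a number 24 percentage points higher from compound 1 to compound 4 (beyond the scatter). Going by these compounds alone, this is the first sign that the position is not indifferent to what it carries: the entering group, with 2 heavy atoms and no ring, goes with more inhibition at the one concentration tested than the leaving group, with 7 heavy atoms and a six-membered non-aromatic ring. No measurement of any property of the two groups accompanies this step, so the numbers offer no reason for it.

This single pair cannot separate the loss of the ring, the smaller heavy-atom count and the arrival of sulfur, as all three change together; a methoxy group, a chlorine atom or a morpholin-4-yl ring at this place would begin to pull them apart. From the compounds shown here alone, it also remains open what a plain hydrogen on this carbon would give, and whether the step holds when the dimethoxyphenyl amide of compound 1 and compound 4 is changed.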